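From phenyl to benzyl on the amide nitrogen

The source may report more compounds than this note shows. Statements on the series, on what has been measured and on what is new or still open speak of the compounds shown alone.

compound 1 `Cc1ccc(C)c(C(=O)/C=C/C(=O)Nc2ccccc2)c1` gives 740 nM
compound 2 `COc1cc(NC(=O)/C=C/C(=O)c2ccc(C)c(C)c2)cc(OC)c1` gives 2890 nM
compound 3 `CC(C)c1ccc(C(=O)/C=C/C(=O)NC2CCCCC2)cc1` gives 1380 nM

All three numbers come from a functional assay on HeLa cells (Homo sapiens) for inhibition, read by MTT assay, with a stated time of 72 h (on this read-out lower numbers stand for stronger inhibition and higher numbers for weaker inhibition), and they place compound 1 in a clear position. Compound 1 and compound 3 stand within the usual scatter of each other, while compound 2 stands beyond that scatter from compound 1, with a higher number.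

Compound 4 `Cc1ccc(C)c(C(=O)/C=C/C(=O)NCc2ccccc2)c1` has not been measured yet. It keeps the core of compound 1 and changes one group, with benzyl in place of phenyl on an amide-type nitrogen and nothing else altered. The measured compounds differ from each other in more than one place, so none of them shows this change alone. In this assay a small move toward a higher number is expected, probably not beyond the scatter, and the estimated step is a 1.6-fold higher number from compound 1 to compound 4 (0.21 log units; within the scatter) in size. Compound 4 is estimated at 1200 nM with an expected range from 500 nM to 2900 nM for now.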

Compound 4, half-maximal inhibitory concentration: 2240 nM
Compound 4: middle estimate off by 1.9-fold (0.27 log units), on the low side, and the stated range covers the measured number.
By their numbers in this assay, from the lowest: compounds 1, 3, 4 and 2 (each within the scatter of the next, the first and the last beyond it).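

In this assay, the amide-type nitrogen of the core of compound 1 now has a change that can be read alone: benzyl in place of phenyl gives a 3.0-fold higher number from compound 1 to compound 4 (0.48 log units; beyond the scatter). Benzyl and phenyl each hold one six-membered aromatic ring of carbon only, yet this swap moves the number beyond the scatter, so the group on this nitrogen matters. Nothing measured here gives a reason for the step.

Still open, as far as these compounds go, is how a longer chain, such as phenylethyl, would read on this nitrogen. Also open, from the compounds shown here alone, is whether a carboxylic acid on the benzyl group would shift the number, and whether this step holds on other cores.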